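This account rests on a few compounds, and the source may have more. Where it says the series, first, only, none or still open, it means among the compounds named here.

For the measured compounds named here, compound 2 `COc1cc2ncnc(Nc3ccc(F)c(Br)c3)c2cc1OCCCCC(=O)Nc1ccc(S(N)(=O)=O)cc1` is the only compound with a number in a functional assay on NCI-H1975 cells (Homo sapiens) for antiproliferative activity, read by MTT assay, with a stated time of 72 h (on this read-out lower numbers stand for stronger inhibition and higher numbers for weaker inhibition), where compound 2 gives 31600 nM. Compound 1 `COc1cc2ncnc(Nc3cccc(F)c3)c2cc1OCCCCC(=O)Nc1ccc(S(N)(=O)=O)cc1` sits at the limit of > 40000 nM in this assay, at which 1 of the 2 values shown sits, so in this assay compound 1 gives > 40000 nM, a limit and not a number. Between those two the step of an at least 1.2-fold lower number from compound 1 to compound 2 (0.10 log units; that floor lies within the scatter) is small. Compound 3 `COc1cc2ncnc(Nc3cccc(C)c3)c2cc1OCCCCC(=O)Nc1ccc(S(N)(=O)=O)cc1` is still to be measured in this assay; it differs from compound 2 by 3-methylphenyl in place of 3-bromo-4-fluorophenyl on a nitrogen on an aromatic ring. Going by the values given here, only that one step bears on this change, and it lay within the scatter, so no step beyond the scatter is expected, a 1.1-fold higher number from compound 2 to compound 3 (0.04 log units; within the scatter). Compound 3 is therefore estimated at 35000 nM, between 15000 nM and 100000 nM.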

Compound 3, half-maximal inhibitory concentration: 32100 nM
Compound 3: middle estimate off by 1.1-fold (0.04 log units), on the high side; the range from low to high includes it.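

In this assay, 3-methylphenyl in place of 3-bromo-4-fluorophenyl on the nitrogen gives a 1.0-fold higher number from compound 2 to compound 3 (0.01 log units; within the scatter), so these two groups cannot be told apart at this position. The step of an at least 1.2-fold lower number from compound 1 to compound 3 (0.09 log units; that floor lies within the scatter) has only a floor, and that floor lies within the scatter, so it does not separate methyl from fluoro on the aromatic carbon. Compound 1 remains a limit and not a number: the limit of > 40000 nM in this assay, at which 1 of the 3 values shown sits. As far as these compounds go, it remains open whether an amine or a carboxylic acid on this phenyl ring, or a longer chain on the shared core, would move the value beyond the scatter.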